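Two side chains on one core, a third awaited

The source may report more compounds than this note shows. Statements on the series, on what has been measured and on what is new or still open speak of the compounds shown alone.

Measured in a toxicity assay on L02 cells (Homo sapiens) for cytotoxicity, read by MTT assay, with a stated time of 72 h; a higher number here means a weaker inhibitor, a lower number a stronger inhibitor:
Compound 1 `CC1(C)OC[C@H](Cn2cc(Cn3c4c(c5ccccc53)C(=O)c3c[n+]([O-])c5ccccc5c3C4=O)nn2)O1`: 470 nM
Compound 2 `CCCN1CCN(CCCCn2c3c(c4ccccc42)C(=O)c2c[n+]([O-])c4ccccc4c2C3=O)CC1`: 6830 nM

Compound 2, at 6830 nM, has the higher of the two numbers, and its gap to compound 1 lies beyond the usual scatter of repeated measurements. For the measured compounds named here, the two compounds share a core but differ in their side chains, and no measured pair differs in one place only. The data therefore give no direct guide to the next change.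

Compound 3 `O=C1c2c[n+]([O-])c3ccccc3c2C(=O)c2c1c1ccccc1n2CCCN1CCC(O)CC1` has not yet been measured. It differs from compound 2 as follows: 4-hydroxypiperidin-1-yl in place of (4-propylpiperazin-1-yl)methyl on a saturated chain carbon, three bonds along the chain from an aromatic nitrogen. In words, this is 4-hydroxypiperidin-1-yl in place of (4-propylpiperazin-1-yl)methyl on a saturated chain carbon, three bonds along the chain from an aromatic nitrogen.

Compound 1 reaches 470 nM on the same core, which shows that a much lower number is possible there. Only a modest move in that direction is expected, as compound 3 still carries a six-membered non-aromatic ring on its chain, like compound 2. The expected size of the change is a 2.3-fold lower number from compound 2 to compound 3 (0.36 log units; beyond the scatter). In this assay, compound 3 is estimated at 3000 nM, with an expected range from 800 nM to 10000 nM.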

Compound 3, half-maximal inhibitory concentration: 120 nM
Estimate against measurement, compound 3: 25-fold (1.40 log units) above, outside the stated range (below it).
By their numbers in this assay, from the lowest: compound 3; then compound 1; then compound 2.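

In this assay, this chain position proves highly sensitive: putting 4-hydroxypiperidin-1-yl in place of (4-propylpiperazin-1-yl)methyl on a saturated chain carbon, three bonds along the chain from an aromatic nitrogen, gives a 57-fold lower number from compound 2 to compound 3 (1.76 log units; beyond the scatter) on the shared core. Both groups hold one six-membered non-aromatic ring and carry no net charge, so the presence of such a ring on the chain does not alone fix the number; what differs is a ring with 1 hetero atom instead of 2, fewer heavy atoms, and 1 hydrogen-bond donor instead of 0. No measurement here accounts for the size of this step.

The change also alters several features at once: cut one bond further out, it reads 3-(4-propylpiperazin-1-yl)propyl to 2-(4-hydroxypiperidin-1-yl)ethyl, so the chain length, the ring and the hydroxyl group cannot be told apart. A plain piperidine without the hydroxyl group on the same chain, or 4-hydroxypiperidin-1-yl on a longer chain, would begin to separate these contributions.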